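A few compounds are considered here, and "the series" means these few. Any claim that something is new, unique, unknown or untested is made for them only; others in the source may bear on it.

Measured so far:
compound 1 `O=C(Cc1cccnc1)c1cc2ccccc2[nH]1` — 13%
compound 2 `O=C(Cc1cccnc1)c1cc2cc([N+](=O)[O-])ccc2[nH]1` — "not active" (no number reported)

In an in vitro assay on P815B cells for inhibition of Indoleamine 2,3-dioxygenase 1 (Mus musculus), tested at 20 uM (on this read-out higher numbers stand for more inhibition at the one concentration tested (going by the name of the read-out) and lower numbers for less inhibition), compound 1 gives 13%. Compound 2 is reported in this assay only as "not active" (no number reported), so no single number places it, and nothing sets a measured distance between compound 2 and compound 1. Compound 3 `O=C(Cc1cccnc1)c1cc2cc(O)ccc2[nH]1` differs from compound 2 by hydroxy in place of nitro on an aromatic carbon. Within the data shown here, no measured step of this kind exists. In this assay a small step, if any, is expected, leaning toward more inhibition but probably not beyond the scatter. Compound 3 is expected to give about 10%, between 0% and 28%.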

Compound 3, a percentage reported as inhibition, at one concentration (the size of the read-out at that concentration, not a potency): "not active" (no number reported)
Nothing numeric was reported for compound 3; no gap can be computed for the estimate.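

Compound 2 and compound 3 are both reported only as "not active" in this assay, so no step can be read between them. The compounds shown leave open how far either group shifts inhibition from the level of compound 1. No supporting evidence bears on this result.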